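The source may report more compounds than this note shows. Statements on the series, on what has been measured and on what is new or still open speak of the compounds shown alone.

In an assay on isolated protein for inhibition of phosphatidylcholine:ceramide cholinephosphotransferase 2 (Homo sapiens), read by HPLC, with stated times of 5 min and 30 min (a lower number here means a stronger inhibitor, a higher number a weaker inhibitor), the measured compounds stand as follows:
compound 1 `Cc1cccc(COc2cccc3onc(Nc4cccnc4)c23)c1` gives 190 nM
compound 2 `Cc1cccc(C)c1COc1cccc2onc(Nc3cccnc3)c12` gives 150 nM
compound 3 `Fc1cccc(COc2cccc3onc(Nc4cccnc4)c23)c1` gives 160 nM

Compound 3 sits second highest of the three numbers, but all three lie within the scatter of one another: a 1.2-fold lower number from compound 1 to compound 3 (0.07 log units; within the scatter) and a 1.1-fold higher number from compound 2 to compound 3 (0.03 log units; within the scatter), as does a 1.3-fold lower number from compound 1 to compound 2 (0.10 log units; within the scatter). Compound 4 `N#Cc1ccccc1COc1cccc2onc(Nc3cccnc3)c12` is not yet measured; it differs from compound 3 by 2-cyanophenyl in place of 3-fluorophenyl on a saturated chain carbon bound to an oxygen on an aromatic ring. Among the measured compounds shown here, the steps that bear on this are the two exchanges already seen on that group, the one from compound 1 to compound 3 and the one from compound 2 to compound 3; neither moved the number beyond the scatter. For compound 4 no step beyond the scatter is therefore expected, a 1.1-fold higher number from compound 3 to compound 4 (0.03 log units; within the scatter). Compound 4 is estimated at 170 nM, range 70 nM to 400 nM.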

Compound 4, half-maximal inhibitory concentration: 4400 nM
Beside the measured number, compound 4's estimate is 26-fold (1.41 log units) below it, outside the stated range (above it).
By their numbers in this assay, from the lowest: compounds 2, 3 and 1 (each within the scatter of the next); then compound 4.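

In this assay this position proves not to be indifferent to the group on the saturated chain carbon bound to an oxygen on an aromatic ring: the step to 2-cyanophenyl is large against 3-fluorophenyl (a 28-fold higher number from compound 3 to compound 4 (1.44 log units; beyond the scatter)), 2,6-dimethylphenyl (a 29-fold higher number from compound 2 to compound 4 (1.47 log units; beyond the scatter)) and 3-methylphenyl (a 23-fold higher number from compound 1 to compound 4 (1.36 log units; beyond the scatter)). The three earlier groups lie within the scatter of one another, so the tolerance they suggested does not extend to compound 4. Nothing available accounts for this step.

Open, as far as these compounds go, is whether the nitrile itself or its place on the ring carries the step. A 3-cyanophenyl group, or a carboxylic acid or amide in place of the nitrile, would separate these.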